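The source may hold more compounds than are shown below. What is called first, only, known or untested is meant among the compounds shown, and "the series" means these compounds.

Measured in a functional assay on the whole organism with Rattus norvegicus as the target; a higher number here means that more compound is needed for the effect, a lower number that less compound is needed:

Compound 1 `CNc1cc(OC)c(C(=O)NC2CCN(Cc3ccccc3)C2)cc1Cl`: 0.016 mg/kg
Compound 2 `COc1cc(N(C)C)c(Cl)cc1C(=O)NC1CCN(Cc2ccccc2)C1`: 0.12 mg/kg
Compound 3 `COc1cc(N(C)C)c(Cl)cc1C(=O)NC1CCN(C2CCCCC2)C1`: 1 mg/kg

Of these three, compound 2 at 0.12 mg/kg holds the middle place, with a lower number for compound 1 and a higher number for compound 3. Compound 4 `CCNc1cc(OC)c(C(=O)NC2CCN(Cc3ccccc3)C2)cc1Cl` has not yet been measured. It has ethylamino in place of dimethylamino on an aromatic carbon, ortho to a chloro group, and the difference from compound 2 counts as follows: ethylamino in place of dimethylamino on an aromatic carbon. The measured step that bears on this concerns the same nitrogen. Methyl in place of hydrogen on that nitrogen gave a 7.5-fold higher number from compound 1 to compound 2 (0.88 log units; beyond the scatter) and was beyond the scatter. Like compound 1, compound 4 has a hydrogen on that nitrogen, so a lower number than that of compound 2 is expected. Among the measured compounds shown here, no measured compound carries ethylamino, however, so the full size of that step is not assumed to return. The other step, an 8.3-fold higher number from compound 2 to compound 3 (0.92 log units; beyond the scatter) with cyclohexyl in place of benzyl, does not bear on the change, as compound 4 keeps the benzyl. The expected step is a 3.4-fold lower number from compound 2 to compound 4 (0.54 log units; beyond the scatter) and its size is only an estimate. For compound 4 the estimated value is 0.035 mg/kg with an expected range from 0.01 mg/kg to 0.12 mg/kg.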

Compound 4, dose for half-maximal effect: 0.1 mg/kg
Estimate against measurement, compound 4: 2.9-fold (0.46 log units) below, within the range that was stated.
By their numbers in this assay, from the lowest: compound 1; then compounds 4 and 2 (each within the scatter of the next); then compound 3.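

With a hydrogen back on the nitrogen, ethylamino in place of dimethylamino gave in this assay a 1.2-fold lower number from compound 2 to compound 4 (0.08 log units; within the scatter) and did not return the number to that of compound 1. Keeping the hydrogen and adding a methyl on the chain carbon gave a 6.3-fold higher number from compound 1 to compound 4 (0.80 log units; beyond the scatter) and adding a methyl on the nitrogen gave a 7.5-fold higher number from compound 1 to compound 2 (0.88 log units; beyond the scatter); both steps lie beyond the scatter. Among these three compounds, then, the hydrogen on the nitrogen does not by itself set the number, for only the methylamino group of compound 1 stands apart from dimethylamino and ethylamino, and no measured evidence here explains this.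

The compounds shown leave open how a plain amino group or a longer chain such as propylamino would sit against methylamino and ethylamino at this position. They also leave open whether cyclohexyl in place of benzyl, seen as an 8.3-fold higher number from compound 2 to compound 3 (0.92 log units; beyond the scatter) with dimethylamino on the ring, would give a step of similar size alongside methylamino or ethylamino.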